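Anilinoquinazoline sulfonamides on lung carcinoma cells: dimethoxy aniline

This account rests on a few compounds, and the source may have more. Where it says the series, first, only, none or still open, it means among the compounds named here.

Measured compounds:
compound 1 `COc1cc2ncnc(Nc3ccc(Cl)c(C(F)(F)F)c3)c2cc1OCCCCC(=O)Nc1ccc(S(N)(=O)=O)cc1` — 3220 nM
compound 2 `COc1cc2ncnc(Nc3ccc(F)cc3)c2cc1OCCCCC(=O)Nc1ccc(S(N)(=O)=O)cc1` — > 40000 nM
compound 3 `COc1cc2ncnc(Nc3ccc(Cl)cc3)c2cc1OCCCCC(=O)Nc1ccc(S(N)(=O)=O)cc1` — 31800 nM

Compound 3 sits at the higher of the two numbers given in a functional assay on NCI-H1975 cells (Homo sapiens) for antiproliferative activity, read by MTT assay, with a stated time of 72 h; on this read-out lower numbers stand for stronger inhibition and higher numbers for weaker inhibition; compound 1 is the nearer neighbour, and the step of a 9.9-fold higher number from compound 1 to compound 3 (0.99 log units; beyond the scatter) is beyond the scatter. For compound 2 the read-out is a limit, (the limit of > 40000 nM in this assay, at which 1 of the 3 values shown sits), not a number. Between compound 2 and compound 3 the step of an at least 1.2-fold lower number from compound 2 to compound 3 (0.09 log units; that floor lies within the scatter) is within the scatter, so no order is drawn between those two.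

Compound 4 `COc1ccc(Nc2ncnc3cc(OC)c(OCCCCC(=O)Nc4ccc(S(N)(=O)=O)cc4)cc23)cc1OC` keeps the shared core and its side chain and changes only the aniline: 3,4-dimethoxyphenyl in place of 4-chlorophenyl on a nitrogen on an aromatic ring. Within the data shown here, no measured step touches the dimethoxy substitution itself. Among the measured compounds shown here, the steps that bear on the aniline are an at least 12-fold higher number from compound 1 to compound 2 (1.09 log units; beyond the scatter) and a 9.9-fold higher number from compound 1 to compound 3 (0.99 log units; beyond the scatter), both large losses on removing the trifluoromethyl group, and an at least 1.2-fold lower number from compound 2 to compound 3 (0.09 log units; that floor lies within the scatter), which shows no separation between the two halogens. Compound 3 already lies close to the limit, so for compound 4 the expected outcome in this assay is a number near compound 3 or a limit, with the step of a 1.2-fold higher number from compound 3 to compound 4 (0.08 log units; within the scatter) not expected to clear the scatter in either direction. The estimate for compound 4 is 38000 nM, within 10000 nM to 120000 nM.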

Compound 4, half-maximal inhibitory concentration: 9230 nM
Beside the measured number, compound 4's estimate is 4.1-fold (0.61 log units) above it; measured number below the stated range.
By their numbers in this assay, from the lowest: compound 1; then compound 4; then compound 3. At a limit, above all of these: compound 2.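

In this assay, the aniline on a nitrogen on an aromatic ring proves more open to change than the two halogen compounds suggested, with a 3.4-fold lower number from compound 3 to compound 4 (0.54 log units; beyond the scatter) and an at least 4.3-fold lower number from compound 2 to compound 4 (0.63 log units; beyond the scatter), so 3,4-dimethoxyphenyl, which carries no halogen and no trifluoromethyl, clears both of the monohalogenated anilines. The gain stops short of the best aniline shown, with a 2.9-fold higher number from compound 1 to compound 4 (0.46 log units; beyond the scatter), so 4-chloro-3-(trifluoromethyl)phenyl keeps the lead in this small set, while 3,4-dimethoxyphenyl takes an intermediate place that the earlier steps, all tied to the trifluoromethyl group, did not reveal. The read-out of compound 2 remains a limit rather than a number, so the true size of its step is unknown: the limit of > 40000 nM in this assay, at which 1 of the 4 values shown sits.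

On these data alone, it remains open whether the gain needs both methoxy groups or whether a single one, as in 4-methoxyphenyl or 3-methoxyphenyl, would carry it, and whether 3-(trifluoromethyl)phenyl without the chloro group would hold the lead of compound 1. Equally open, as far as these compounds go, is how these anilines behave when the side chain is changed, for example with a longer chain or with a carboxylic acid in place of the sulfonamide.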